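Shortening an Alkoxy Chain: Isopropoxy to Methoxy

The compounds below may be only part of what the source reports. "The series", "measured", "known", "first", "only" and "open" are said of these compounds alone.

Three compounds built on a shared core were tested in a functional assay on K562 cells (Homo sapiens) for antiproliferative activity, read by MTT assay, with a stated time of 72 h; on this read-out higher numbers stand for weaker inhibition and lower numbers for stronger inhibition. Compound 1 `COc1cc(-n2ncnc2-c2cccc([N+](=O)[O-])c2)cc(OC)c1OC` reaches only a limit of the assay, > 10000 nM. Compound 3 `COc1cc(-c2ncnn2-c2ccc(Cl)c(Cl)c2)cc(OC)c1OC` likewise gives just a limit, > 10000 nM. Within the data shown here, compound 2 `COc1cc(-n2ncnc2-c2ccc(OC(C)C)cc2)cc(OC)c1OC` is the one compound with a true number, 800 nM, and so stands alone among the three, the other two sitting at the limit of > 10000 nM in this assay, at which 2 of the 3 values shown sit. Compound 4 `COc1ccc(-c2ncnn2-c2cc(OC)c(OC)c(OC)c2)cc1` differs from compound 2 by methyl in place of isopropyl on an oxygen on an aromatic ring. Among the measured compounds shown here, no step between measured compounds is available to guide the direction, so the expectation for compound 4 in this assay is a shift no larger than the usual scatter. Compound 4 is accordingly estimated at 600 nM, within 150 nM to 2400 nM, an expected step of a 1.3-fold lower number from compound 2 to compound 4 (0.12 log units; within the scatter).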

Compound 4, half-maximal inhibitory concentration: 950 nM
Compound 4: the middle estimate sits 1.6-fold (0.20 log units) below what was measured; the measured number falls inside the stated range.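

The change from isopropoxy to methoxy gives a 1.2-fold higher number from compound 2 to compound 4 (0.07 log units; within the scatter) in this assay. On this oxygen on an aromatic ring, the two-carbon-shorter reach of methyl therefore makes no readable difference, and this place tolerates both groups at this level of inhibition. Nothing given here bears on a cause for this.

The compounds shown leave open whether a longer chain such as butoxy, a free hydroxyl or an amine at the same place would keep that level. They also leave open whether a carboxylic acid would.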